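A few compounds are considered here, and "the series" means these few. Any claim that something is new, unique, unknown or untested is made for them only; others in the source may bear on it.

Measured compounds:
Compound 1, `OCCNc1nnc2nncn2n1` — for compound 1 the value is 3310 nM.
Compound 2, `c1nnc2nnc(N3CCCC3)nn12` — for compound 2 the value is 4290 nM.

Both values come from a functional assay on BeWo cells (Homo sapiens) for inhibition, read by MTT assay, with a stated time of 72 h; on this read-out higher numbers stand for weaker inhibition and lower numbers for stronger inhibition. Compound 1 holds the lower of the two numbers, but its nearest neighbour, compound 2, lies within the usual scatter of it, so the two cannot be told apart on this read-out and neither is set above the other. Within the data shown here, no step between two measured compounds differing in a single place has been recorded, so there is no measured change to lean on.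

Compound 3, `CC(Nc1nnc2nncn2n1)C(=O)O`, is the next compound to be measured in this assay . It departs from compound 1 in a single place: 1-carboxyethyl in place of 2-hydroxyethyl on a nitrogen on an aromatic ring. Among the measured compounds shown here, with no comparable step recorded, the change is taken as neutral. Compound 3 is expected to give about 4000 nM, within a range from 1500 nM to 11000 nM. The step of a 1.2-fold higher number from compound 1 to compound 3 (0.08 log units; within the scatter) is estimated to fall within the scatter, with no clear direction, and the finished measurement will show whether that expectation holds.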

Compound 3, half-maximal inhibitory concentration: 82200 nM
The estimate for compound 3 lay 21-fold (1.31 log units) below the measured number; the whole stated range lies below it.
By their numbers in this assay, from the lowest: compounds 1 and 2 (each within the scatter of the next); then compound 3.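

In this assay, the position on the nitrogen on an aromatic ring proves sensitive to what it carries: replacing 2-hydroxyethyl with 1-carboxyethyl gives a 25-fold higher number from compound 1 to compound 3 (1.40 log units; beyond the scatter), so inhibition is clearly weaker after this change. Among these compounds, the two earlier compounds, which lie within the scatter of each other, gave no sign of a change this large, and no earlier step existed to show it. The two groups have the same counts of hydrogen-bond donors and acceptors, and neither has a ring or a net charge, so the step goes with the larger group and its double bond rather than with any difference in those counts, and nothing measured here explains it.

The swap alters the shape of the chain and its end group at once, and the compounds shown do not separate these two changes. On these data alone, it remains open whether a 2-carboxyethyl group, a primary amide or a methyl ester at this position would give a number close to that of compound 1 or close to that of compound 3.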